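A few compounds are considered here, and "the series" means these few. Any claim that something is new, unique, unknown or untested is made for them only; others in the source may bear on it.

Compound 3, `CC1CCN(Cc2c(-c3nnc(SC(C)C)n3-c3ccccc3)n(C)c3ccccc23)CC1`, is the starting point of this step. In a physicochemical assay for lipophilicity (on this read-out higher numbers stand for higher lipophilicity and lower numbers for lower lipophilicity), compound 3 gives 5.96, the second highest of the three measured numbers. Compound 1, `COc1cccc(CNCc2c(-c3nnc(SC(C)C)n3-c3ccccc3)n(C)c3ccccc23)c1`, gives 6.27 in this assay, and the change a number 0.31 log units lower from compound 1 to compound 3 (beyond the scatter) is modest. Compound 2, `CC(C)Sc1nnc(-c2c(CNc3cnccn3)c3ccccc3n2C)n1-c1ccccc1`, gives 4.22 in this assay, and the change a number 1.74 log units higher from compound 2 to compound 3 (beyond the scatter) is large.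

Compound 4 is `CC(C)Sc1nnc(-c2c(CNc3nc4ccccc4[nH]3)c3ccccc3n2C)n1-c1ccccc1`. It differs from compound 3 in one place: (1H-benzimidazol-2-yl)amino in place of 4-methylpiperidin-1-yl on a saturated chain carbon bound to an aromatic carbon.

Among the compounds with values here, the step that bears most directly on this change is the one between compound 2 and compound 3, where an aromatic amino group was swapped for the piperidine ring and the number rose by a number 1.74 log units higher from compound 2 to compound 3 (beyond the scatter). The change from compound 1 to compound 2, a number 2.05 log units lower from compound 1 to compound 2 (beyond the scatter), likewise shows a large drop when an aromatic amino group enters. Going the other way here, a large drop in this assay is expected for compound 4, estimated at a number 1.06 log units lower from compound 3 to compound 4 (beyond the scatter), giving an expected value for compound 4 of 4.9, with a range from 4.2 to 5.6.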

Compound 4, partition coefficient: 5.94
Compound 4: middle estimate off by 1.04 log units, on the low side, and the stated range ends below it.
By their numbers in this assay, from the lowest: compound 2; then compounds 4 and 3 (each within the scatter of the next); then compound 1.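

In this assay, (1H-benzimidazol-2-yl)amino in place of 4-methylpiperidin-1-yl on the saturated chain carbon gives a number 0.02 log units lower from compound 3 to compound 4 (within the scatter) and so shows that an aromatic amino group here need not come with a large drop. Changing the group on the amine nitrogen from pyrazin-2-yl to 1H-benzimidazol-2-yl gives a number 1.72 log units higher from compound 2 to compound 4 (beyond the scatter) and ties the low number of compound 2 to that particular group, not to every aromatic group at this nitrogen. Replacing 3-methoxybenzyl with 1H-benzimidazol-2-yl gives a number 0.33 log units lower from compound 1 to compound 4 (beyond the scatter) as a modest step, whereas pyrazin-2-yl brought a large one.

On these data alone, it remains open whether a pyridin-2-yl or quinoxalin-2-yl group on the same nitrogen would fall near compound 2 or near compound 4. No measurement shown here explains the gap between the two aromatic groups.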